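Swapping the amide side chain on a bromo-bearing core

The compounds below may be only part of what the source reports. "The series", "measured", "known", "first", "only" and "open" are said of these compounds alone.

Compound 1 `CCC(CO)NC(=O)c1cc2cc(Br)ccc2oc1=N` is the starting point. In an assay on CHO cells for displacement of a labelled ligand from adenosine receptor A1 (Homo sapiens), read by scintillation counting, with a stated time of 60 min, tested at 10 uM (on this read-out higher numbers stand for more inhibition at the one concentration tested (going by the name of the read-out) and lower numbers for less inhibition), compound 1 gives 20%. Among the three numbers measured, compound 1 stands second highest. Its nearest neighbour is compound 2 `CCC(CO)NC(=O)c1cc2cc(Cl)ccc2oc1=N`, which differs from compound 1 only in carrying chloro in place of bromo on an aromatic carbon; in this assay compound 2 gives 7%. That step is a number 13 percentage points lower from compound 1 to compound 2 (beyond the scatter). Compound 3 `COc1cccc2cc(C(=O)Nc3c(C#N)ncn3-c3ccc(F)cc3)c(=N)oc12`, built on a different pattern, gives 46% in this assay and lies furthest from compound 1.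

Compound 4 `N=c1oc2ccc(Br)cc2cc1C(=O)NCC(O)CO` has not yet been measured. It keeps the bromo-bearing core of compound 1 and changes only the group on the amide-type nitrogen: 2,3-dihydroxypropyl in place of 1-(hydroxymethyl)propyl on an amide-type nitrogen. Going by the values given here, the one measured step, the halogen swap, concerns a different part of the molecule and says nothing directly about what a change at the amide-type nitrogen does; no pair among the measured compounds differs only in that group. Among the compounds with values here, with no step that bears on this change, the expectation for compound 4 is a step of no change at the digits printed from compound 1 to compound 4 (within the scatter), that is, none beyond the scatter. Compound 4 is therefore estimated to give 20% in this assay, with a range from 5% to 40%.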

Compound 4, a percentage reported as inhibition, at one concentration (the size of the read-out at that concentration, not a potency): 11%
The estimate for compound 4 lay 9 percentage points above the measured number, and the stated range covers the measured number.
By their numbers in this assay, from the lowest: compounds 2, 4 and 1 (each within the scatter of the next, the first and the last beyond it); then compound 3.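

Going by these compounds alone, this result is the first reading at the amide-type nitrogen, a place the halogen swap left untouched. In this assay the change from 1-(hydroxymethyl)propyl to 2,3-dihydroxypropyl comes out as a number 9 percentage points lower from compound 1 to compound 4 (within the scatter) and so cannot be told apart from no change, even though the entering group has 2 hydrogen-bond donors against 1 in the group that leaves, at the same count of 5 heavy atoms. No measurement shown here accounts for this outcome.

Open, as far as these compounds go, is whether any group on this nitrogen moves the number beyond the scatter, since a single pair of similar hydroxylated chains says little about a longer chain, an amine or a carboxylic acid in the same place. Also open, from the compounds shown here alone, is how 2,3-dihydroxypropyl behaves with chloro in place of bromo on the shared core, and whether the halogen step seen with the 1-(hydroxymethyl)propyl side chain holds there as well.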